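Swapping the Aryl Group on the Triazole Nitrogen

A few compounds are considered here, and "the series" means these few. Any claim that something is new, unique, unknown or untested is made for them only; others in the source may bear on it.

In a functional assay on MCF7 cells (Homo sapiens) for antiproliferative activity, read by MTT assay, with a stated time of 48 h (on this read-out higher numbers stand for weaker inhibition and lower numbers for stronger inhibition), compound 1 `Cc1cccc(-n2nncc2CN2C(=O)C3(C(C#N)=C(N)Oc4c(N)cc5nc6ccccc6nc5c43)c3ccccc32)c1` gives > 50000 nM, a limit of the assay rather than a number.
Compound 2 `N#CC1=C(N)Oc2c(N)cc3nc4ccccc4nc3c2C12C(=O)N(Cc1cnnn1-c1ccccc1Br)c1ccccc12` gives 30700 nM in this assay.
Compound 3 `Cc1cc(C)cc(-n2nncc2CN2C(=O)C3(C(C#N)=C(N)Oc4c(N)cc5nc6ccccc6nc5c43)c3ccccc32)c1` gives > 50000 nM in this assay, again a limit and not a number.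

Compound 3 therefore stands at the limit of > 50000 nM in this assay, at which 2 of the 3 values shown sit, so its position can only be bounded, not placed. Compound 4 `N#CC1=C(N)Oc2c(N)cc3nc4ccccc4nc3c2C12C(=O)N(Cc1cnnn1-c1ccc(F)c(Cl)c1)c1ccccc12` differs from compound 3 in one place: 3-chloro-4-fluorophenyl in place of 3,5-dimethylphenyl on an aromatic nitrogen. For the measured compounds named here, three measured steps bear on changes at this same aromatic nitrogen. The step that the two limits leave unreadable from compound 1 to compound 3 cannot be read. The step of an at least 1.6-fold lower number from compound 1 to compound 2 (0.21 log units; that floor lies within the scatter) and the step of an at least 1.6-fold higher number from compound 2 to compound 3 (0.21 log units; that floor lies within the scatter) each have a floor that sits within the scatter. Nothing among these three steps shows a change beyond the scatter for swapping one phenyl group for another at this position, so no step beyond the scatter is expected here either. Compound 4 is estimated at 40000 nM, expected to fall between 15000 nM and 100000 nM. That estimate means an expected step of an at least 1.2-fold lower number from compound 3 to compound 4 (0.09 log units; that floor lies within the scatter), with a real chance that the assay again reports only a limit.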

Compound 4, half-maximal inhibitory concentration: 17800 nM
The estimate for compound 4 lay 2.2-fold (0.35 log units) above the measured number; the range from low to high includes it.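

In this assay, changing the aryl group on this aromatic nitrogen now gives a step beyond the scatter: 3-chloro-4-fluorophenyl in place of 3,5-dimethylphenyl gives an at least 2.8-fold lower number from compound 3 to compound 4 (0.44 log units; beyond the scatter), and in place of 3-methylphenyl it gives an at least 2.8-fold lower number from compound 1 to compound 4 (0.44 log units; beyond the scatter). Both sizes are floors, so the true changes may be larger. The two halogen-bearing groups cannot be ordered, as a 1.7-fold lower number from compound 2 to compound 4 (0.24 log units; within the scatter) stays within the scatter, while the two methyl-bearing compounds, compound 1 and compound 3, remain limits rather than numbers: the limit of > 50000 nM in this assay, at which 2 of the 4 values shown sit.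

The compounds shown do not separate the chlorine from the fluorine, so which of them matters, if either alone does, stays open. As far as these compounds go, what an amine or a carboxylic acid on this phenyl ring would do also remains unknown.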